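Swapping the Phenylcarbamoyl Arm for a Pyridinyl Amine

A few compounds are considered here, and "the series" means these few. Any claim that something is new, unique, unknown or untested is made for them only; others in the source may bear on it.

Compound 1 `O=C(Nc1ccccc1)c1cnc(NCc2c(F)ccc3c2CCO3)n2cnnc12`: 4.1
Compound 2 `CNC(=O)c1cc(-c2cnc(NCc3c(F)ccc4c3CCO4)c3cn[nH]c(=O)c23)n(C)n1`: 2.1

In a physicochemical assay for lipophilicity, using the shake flask method, in phosphate buffer, measured as octanol-water partition, with a stated time of 30 min, at pH 7.4 (a higher number here means a more lipophilic compound, a lower number a more polar compound), compound 1 gives 4.1, the higher of the two numbers, with compound 2 giving 2.1, beyond the scatter below it. Compound 3 `CN(c1cccnc1)c1cnc(NCc2c(F)ccc3c2CCO3)n2cnnc12` has not been measured. It differs from compound 1 in one place: methyl(pyridin-3-yl)amino in place of phenylcarbamoyl on an aromatic carbon. Among the measured compounds shown here, there is no measured pair showing this change, so the size of the step is a judgement. Compound 3 is expected to be more polar than compound 1, with a step from compound 1 to compound 3 of a number 0.90 log units lower from compound 1 to compound 3 (beyond the scatter). The estimate for compound 3 is 3.2, within 2.5 to 3.9.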

Compound 3, distribution coefficient: 2.6
Compound 3: the middle estimate sits 0.60 log units above what was measured, within the range that was stated.
By their numbers in this assay, from the lowest: compound 2; then compound 3; then compound 1.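

In this assay, the exchange of phenylcarbamoyl for methyl(pyridin-3-yl)amino gives a step of a number 1.50 log units lower from compound 1 to compound 3 (beyond the scatter), so this aromatic carbon of the shared core is a place where one change alone moves the read-out by a large amount. The earlier pair differed in more than one place and could not show this. Nothing available here accounts for the size of the step. The compounds shown leave open which part of the exchange carries the step. A methyl(phenyl)amino group at this position, with a carbon-only ring, would separate the ring nitrogen from the loss of the amide.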